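Dropping One Methoxy Group from Compound 2

A few compounds are considered here, and "the series" means these few. Any claim that something is new, unique, unknown or untested is made for them only; others in the source may bear on it.

Compound 1 `COc1cc(Nc2nnc(Cl)c(Nc3cc(OC)c(OC)c(OC)c3)n2)cc(OC)c1OC`: 34300 nM
Compound 2 `COc1cccc(Nc2nnc(Cl)c(Nc3cc(OC)c(OC)c(OC)c3)n2)c1`: 11300 nM

Among the compounds with values here, in a functional assay on PC-3 cells (Homo sapiens) for inhibition, read by MTT assay, with a stated time of 48 h (a lower number here means a stronger inhibitor, a higher number a weaker inhibitor), compound 2 gives the lower of the two numbers so far, and compound 1 sits above it by a margin beyond the usual scatter. Compound 3 `COc1cc(Nc2nc(Nc3ccccc3)nnc2Cl)cc(OC)c1OC` is the next candidate and differs from compound 2 in a single place: hydrogen in place of methoxy on an aromatic carbon. Within the data shown here, no measured pair shows this change, so its effect can only be judged from the two values in hand, which show that paring methoxy groups off this ring did not hurt on the way from compound 1 to compound 2. The step of a 1.4-fold higher number from compound 2 to compound 3 (0.15 log units; within the scatter) is therefore expected to be small, with a slight lean toward a weaker inhibitor, and not clearly beyond the scatter. Compound 3 is estimated at 16000 nM, with a likely range from 5000 nM to 50000 nM.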

Compound 3, half-maximal inhibitory concentration: 9750 nM
For compound 3 the middle estimate is 1.6-fold (0.22 log units) above the measured one, within the range that was stated.
By their numbers in this assay, from the lowest: compounds 3 and 2 (each within the scatter of the next); then compound 1.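

Hydrogen in place of methoxy on an aromatic carbon gives a 1.2-fold lower number from compound 2 to compound 3 (0.06 log units; within the scatter) in this assay, the first direct reading of this change. At this place, meta to a large group, the 3-methoxyphenyl and phenyl forms therefore cannot be told apart in this assay, so the methoxy group is not needed to hold the level of inhibition seen in this pair. The compounds shown offer no measurement that accounts for this result.

Going by these compounds, whether an amine, a carboxylic acid or a longer chain at this place would move the number beyond the scatter remains open. So does whether the same exchange of methoxy for hydrogen would read alike elsewhere on the shared core.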